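The compounds below may be only part of what the source reports. "The series", "measured", "known", "first", "only" and "open" are said of these compounds alone.

Series notes. In an assay on membranes from striatum (strain Sprague-Dawley) for displacement of a labelled ligand from sodium-dependent dopamine transporter (Rattus norvegicus), read by scintillation counting, with a stated time of 120 min (a higher number here means a weaker inhibitor, a lower number a stronger inhibitor), compound 1 `O=C(c1cc2ccccc2[nH]1)N1CCC(NCCSC(c2ccc(F)cc2)c2ccc(F)cc2)CC1` gives 177 nM, compound 2 `Fc1ccc(C(SCCNC2CCN(Cc3cc4ccccc4[nH]3)CC2)c2ccc(F)cc2)cc1` gives 179 nM and compound 3 `CC(C)(C)C(=O)N1CCC(NCCSC(c2ccc(F)cc2)c2ccc(F)cc2)CC1` gives 352 nM. Compound 3 carries the highest of the three numbers, yet both steps to it stay within the scatter: a 2.0-fold higher number from compound 1 to compound 3 (0.30 log units; within the scatter) and a 2.0-fold higher number from compound 2 to compound 3 (0.29 log units; within the scatter). Compound 4 `CC(C)(C)CN1CCC(NCCSC(c2ccc(F)cc2)c2ccc(F)cc2)CC1` differs from compound 3 by neopentyl in place of (tert-butyl)carbonyl on an amine nitrogen in a ring. The measured step that bears on this is the exchange of the carbonyl for a methylene on the ring amine, a 1.0-fold higher number from compound 1 to compound 2 (0.00 log units; within the scatter), which was within the scatter. On that basis no step beyond the scatter is expected in this assay. Compound 4 is therefore estimated at 300 nM, with a range from 120 nM to 750 nM. The expected step is a 1.2-fold lower number from compound 3 to compound 4 (0.07 log units; within the scatter).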

Compound 4, inhibition constant: 279 nM
Beside the measured number, compound 4's estimate is 1.1-fold (0.03 log units) above it, within the range that was stated.
By their numbers in this assay, from the lowest: compounds 1, 2, 4 and 3 (each within the scatter of the next).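

In this assay, the neopentyl and (tert-butyl)carbonyl groups on the ring amine nitrogen stay within the scatter, with a 1.3-fold lower number from compound 3 to compound 4 (0.10 log units; within the scatter), so the carbonyl exchange now holds with a tert-butyl end as well as with 1H-indol-2-yl. Compound 4 also stays within the scatter of both indole compounds, with a 1.6-fold higher number from compound 2 to compound 4 (0.19 log units; within the scatter) and a 1.6-fold higher number from compound 1 to compound 4 (0.20 log units; within the scatter), so among these compounds this position tolerates all four groups. No measurement here accounts for this. Still open, as far as these compounds go, is whether a primary amine, a carboxylic acid or a longer chain at this nitrogen would produce a step beyond the scatter.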